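Methoxy Added to a Second Core: A Tempered Expectation

This account rests on a few compounds, and the source may have more. Where it says the series, first, only, none or still open, it means among the compounds named here.

The study compares two cores that carry the same dimethoxy-substituted aromatic ring through a trans double bond. Compound 1 `COc1ccc(/C=C/C2CC(=O)C=CO2)cc1OC` and compound 3 `COc1ccc(/C=C/C2CC=CC(=O)O2)cc1OC` have the same atoms joined differently; the difference between the two cores is not broken down here. In an ADME assay on HaCaT cells (Homo sapiens) for inhibition, read by sulforhodamine B assay, with a stated time of 48 h (a lower number here means a stronger inhibitor of growth, a higher number a weaker inhibitor of growth), compound 1 gives 134 uM, while compound 3 gives 63 uM, the lowest of the three numbers measured, and compound 2 `COc1cc(/C=C/C2CC(=O)C=CO2)cc(OC)c1OC` gives 155 uM.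

Compound 2 arises from compound 1 by methoxy in place of hydrogen on an aromatic carbon. In this assay the result was a 1.2-fold higher number from compound 1 to compound 2 (0.06 log units; within the scatter), so this addition left the growth inhibition essentially unchanged on that core.

Compound 4 `COc1cc(OC)c(OC)cc1/C=C/C1CC=CC(=O)O1` arises from compound 3 by the same kind of change, (methoxy in place of hydrogen on an aromatic carbon). The change is not the same: here the entering group is ortho to a group of 9 heavy atoms, meta to a methoxy group and para to a methoxy group, whereas in compound 2 it is ortho to a methoxy group, meta to a group of 9 heavy atoms and meta to a methoxy group. The expectation for compound 4 in this assay rests on compound 3 with 63 uM and on the step of a 1.2-fold higher number from compound 1 to compound 2 (0.06 log units; within the scatter), which stayed within the scatter; the expected step is therefore small, about a 1.1-fold higher number from compound 3 to compound 4 (0.06 log units; within the scatter). Compound 4 is estimated at 72 uM, with a likely range from 36 uM to 145 uM.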

Compound 4, concentration for growth inhibition (reported as GI): 46.9 uM
For compound 4 the middle estimate is 1.5-fold (0.19 log units) above the measured one; measured number inside the range.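

In this assay the addition of methoxy in place of hydrogen on the second core gave a 1.3-fold lower number from compound 3 to compound 4 (0.13 log units; within the scatter), so growth inhibition stayed essentially unchanged on this core as well. Set beside the earlier step, the new one does not differ from it: the same change on two cores in this assay, a 1.2-fold higher number (0.06 log units; within the scatter) from compound 1 to compound 2 and a 1.3-fold lower number (0.13 log units; within the scatter) from compound 3 to compound 4, 1.6-fold (0.19 log units) apart, within the scatter of two such steps

This shows that, across these two pairs, the change carried from one core to the other as a step too small to read. It does not show that the two cores respond alike in general, since the entering methoxy stands in different surroundings in the two pairs, and in compound 4 it is ortho to a group of 9 heavy atoms, meta to a methoxy group and para to a methoxy group; nor can two steps that stay within the scatter tell how a change with a clear effect would carry over.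

The compounds shown leave open what the same ring would do with methoxy entering at one and the same place on both cores. They also leave open whether an amine, a carboxylic acid or a longer chain such as ethoxy in place of that hydrogen would move the number on either core, and whether any such step would carry from one core to the other.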